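This account rests on a few compounds, and the source may have more. Where it says the series, first, only, none or still open, it means among the compounds named here.

Working notes on the series. For the measured compounds named here, compound 3 `Cc1cc(CNC(=S)CCc2ccc(C(C)(C)C)cc2)cc(C)c1NS(C)(=O)=O` gives 2900 nM in a functional assay for antagonist activity at transient receptor potential cation channel subfamily V member 1 (Rattus norvegicus) (a lower number here means a stronger inhibitor, a higher number a weaker inhibitor), the highest of the three numbers so far; compound 2 `CC(C)(C)c1ccc(CCC(=S)NCc2ccc(NS(C)(=O)=O)c(C(F)(F)F)c2)cc1` gives 940 nM and compound 1 `CC(C)(C)c1ccc(CCC(=S)NCc2ccc(NS(C)(=O)=O)c(Cl)c2)cc1` gives 96 nM. Compound 4 `Cc1cc(CNC(=S)CCc2ccc(C(C)(C)C)cc2)cc(Cl)c1NS(C)(=O)=O` differs from compound 3 by chloro in place of methyl on an aromatic carbon. Going by the values given here, the only measured step, a 9.8-fold higher number from compound 1 to compound 2 (0.99 log units; beyond the scatter), concerns a different exchange and does not bear on this one; no pair of measured compounds isolates methyl against chloro at this position. What the numbers show is that the chloro-bearing compound 1 sits far lower than the dimethyl compound 3, so a modest move downward is expected, a 2.9-fold lower number from compound 3 to compound 4 (0.46 log units; beyond the scatter). Compound 4 is estimated at 1000 nM, with a range from 300 nM to 3500 nM in this assay.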

Compound 4, half-maximal inhibitory concentration: 80 nM
Estimate against measurement, compound 4: 13-fold (1.10 log units) above, and the stated range ends above it.
By their numbers in this assay, from the lowest: compounds 4 and 1 (each within the scatter of the next); then compound 2; then compound 3.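

In this assay, the exchange of methyl for chloro ortho to the methanesulfonamido group is far larger than the earlier values suggested, with a 36-fold lower number from compound 3 to compound 4 (1.56 log units; beyond the scatter). A methyl on the ring alongside that chloro changes little, with a 1.2-fold lower number from compound 1 to compound 4 (0.08 log units; within the scatter), so among these compounds the high number of compound 3 appears only where no chloro is present. No measurement here explains why this exchange is so large.

Still open, going by these compounds, is how a bromo, a methoxy or a fluoro would compare with chloro at this position. Also open, on these data alone, is whether the large step holds with a different group on the other side of the thioamide.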